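Pyridin-3-yl in place of propyl: an expected value

This account rests on a few compounds, and the source may have more. Where it says the series, first, only, none or still open, it means among the compounds named here.

Compound 1: `C/C(=C\C(=O)Nc1ccccc1OCCCC(=O)O)c1ccc2c(ccn2Cc2ccc(C)cc2)c1` gives 88 nM in an assay on Prostate gland for inhibition of steroid 5-alpha-reductase (Rattus norvegicus); on this read-out higher numbers stand for weaker inhibition and lower numbers for stronger inhibition.
Compound 2: `CCCC(c1ccccc1)n1ccc2cc(/C(C)=C/C(=O)Nc3ccccc3OCCCC(=O)O)ccc21` gives 9.1 nM in this assay.

Within the data shown here, of the two numbers measured so far, compound 2 stands lowest; the single measured step, a 9.7-fold lower number from compound 1 to compound 2 (0.99 log units; beyond the scatter), sets it apart from compound 1. Compound 3, `C/C(=C\C(=O)Nc1ccccc1OCCCC(=O)O)c1ccc2c(ccn2C(c2ccccc2)c2cccnc2)c1`, differs from compound 2 in one place: pyridin-3-yl in place of propyl on a saturated chain carbon bound to an aromatic carbon and an aromatic nitrogen. The step from compound 1 to compound 2 replaced the whole group on the aromatic nitrogen and so bears only loosely on this narrower exchange, which keeps one aromatic ring on the saturated carbon and swaps the other branch. Among the measured compounds shown here, with no closer precedent, the expected step is small and within the scatter, leaning slightly weaker: a 1.5-fold higher number from compound 2 to compound 3 (0.19 log units; within the scatter). The estimate for compound 3 in this assay is therefore 14 nM, with a range from 4 nM to 60 nM.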

Compound 3, half-maximal inhibitory concentration: 47 nM
Compound 3: the middle estimate sits 3.4-fold (0.53 log units) below what was measured; the measured number falls inside the stated range.
By their numbers in this assay, from the lowest: compound 2; then compounds 3 and 1 (each within the scatter of the next).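

In this assay, the saturated chain carbon bound to an aromatic carbon and an aromatic nitrogen proves sensitive to its second branch: with the phenyl kept in place, pyridin-3-yl for propyl gives a 5.2-fold higher number from compound 2 to compound 3 (0.71 log units; beyond the scatter). The earlier step replaced the whole group on the aromatic nitrogen, so it could not isolate this branch. This exchange changes the heavy-atom count, adds a ring and adds a hydrogen-bond acceptor all at once, and nothing available explains the rise or assigns it to any one of these changes.

The compounds shown leave open whether the ring itself or its nitrogen accounts for the step, which a phenyl on this carbon would help to separate. As far as these compounds go, it also remains open how an ethyl or a butyl there would compare with the propyl of compound 2.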